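A few compounds are considered here, and "the series" means these few. Any claim that something is new, unique, unknown or untested is made for them only; others in the source may bear on it.

Three compounds were tested in a functional assay on THP-1 cells (Homo sapiens) for inhibition, read by sulforhodamine B assay, with a stated time of 48 h, tested at 50 uM; a higher number here means more inhibition of growth at the concentration tested, a lower number less inhibition of growth. Compound 3 `COc1cc(/C=C/C(=O)/C=C/c2ccco2)ccc1OCc1cn(CCCCCOc2cc(=O)oc3ccccc23)nn1` gives 39%, and compound 1 `COc1ccccc1/C=C/C(=O)/C=C/c1ccc(OCc2cn(CCCCCOc3cc(=O)oc4ccccc34)nn2)c(OC)c1` gives 37%. Compound 1 differs from compound 3 by 2-methoxyphenyl in place of furan-2-yl on a double-bonded chain carbon bound to a double-bonded chain carbon, and this change gave a number 2 percentage points lower from compound 3 to compound 1 (within the scatter). Compound 2 `COc1cc(/C=C/C(=O)/C=C/c2ccco2)ccc1OCc1cn(CCOc2cc(=O)oc3ccccc23)nn1` gives 78%, the highest of the three numbers; the difference between the core of compound 2 and the core of compound 3 is not broken down here. Compound 4 `COc1ccccc1/C=C/C(=O)/C=C/c1ccc(OCc2cn(CCOc3cc(=O)oc4ccccc34)nn2)c(OC)c1` has not yet been measured. It differs from compound 2 by 2-methoxyphenyl in place of furan-2-yl on a double-bonded chain carbon bound to a double-bonded chain carbon, the same change, at the same place, as from compound 3 to compound 1. Resting on the step of a number 2 percentage points lower from compound 3 to compound 1 (within the scatter), which lay within the scatter, the expected step is a number 6 percentage points lower from compound 2 to compound 4 (within the scatter). Compound 4 is therefore estimated at 72%, with a likely range from 45% to 88%.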

Compound 4, percent growth inhibition at one concentration: 75%
Beside the measured number, compound 4's estimate is 3 percentage points below it; the measured number falls inside the stated range.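

In this assay, 2-methoxyphenyl in place of furan-2-yl gave a number 3 percentage points lower from compound 2 to compound 4 (within the scatter), and the change behaved alike on both cores: the same change on two cores in this assay, a number 2 percentage points lower (within the scatter) from compound 3 to compound 1 and a number 3 percentage points lower (within the scatter) from compound 2 to compound 4, 1 percentage points apart, within the scatter of two such steps

This shows that the swap left the number in place on these two cores, whether the number was high or low. It does not show that the same would hold on any other core, in another assay or at another concentration, and two pairs cannot establish a general rule for the series.

From the compounds shown here alone, what a phenyl ring carrying an amine or a carboxylic acid would do at this place remains open. So does whether the change would carry over to a core with a chain longer than that of compound 3.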